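Swapping the aryl amide group in a diamine linker series

A few compounds are considered here, and "the series" means these few. Any claim that something is new, unique, unknown or untested is made for them only; others in the source may bear on it.

Compound 1 `Nc1ccccc1NC(=O)CCCNCC(=O)Nc1cc(Cl)ccc1Cl` and compound 2 `Nc1ccccc1NC(=O)CCCNCC(=O)Nc1ccccc1Cl` share the same core and differ only by a chlorine on the aromatic ring. Among the measured compounds shown here, in a functional assay on the whole organism (Ehrlich cells, Mus musculus) for antiproliferative activity, with a stated time of 24 h, at a dose of 0.2 mmol/kg by the intraperitoneal route (on this read-out higher numbers stand for more inhibition at the one dose given (going by the name of the read-out) and lower numbers for less inhibition), compound 1 gives 50.9%, whereas compound 2 gives 12.7%, the lower of the two numbers measured so far. For the measured compounds named here, the one measured step, a number 38.2 percentage points lower from compound 1 to compound 2 (beyond the scatter), shows that losing a chloro there cost a great deal of inhibition. Compound 3 `COc1ccc(NC(=O)CNCCCC(=O)Nc2ccccc2N)cc1` differs from compound 2 by 4-methoxyphenyl in place of 2-chlorophenyl on an amide-type nitrogen. Going by the values given here, no measured step addresses a methoxy group, so the step from compound 1 to compound 2 bears on it only loosely, as a sign that the aryl group matters. Compound 3 is therefore expected to stay near compound 2, with the estimated step of a number 2.3 percentage points higher from compound 2 to compound 3 (within the scatter), and its estimated inhibition is 15% (range 0% to 40%).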

Compound 3, a percentage reported as inhibition, in the whole organism at one dose (the size of the read-out at that dose, not a potency): 63.3%
Compound 3: middle estimate off by 48.3 percentage points, on the low side; the whole stated range lies below it.
By their numbers in this assay, from the lowest: compound 2; then compound 1; then compound 3.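

At the amide-type nitrogen whose other neighbour is the carbonyl carbon, the chlorine step alone had suggested that chloro groups on the aryl ring drive the inhibition, but in this assay the change to 4-methoxyphenyl from 2-chlorophenyl gives a number 50.6 percentage points higher from compound 2 to compound 3 (beyond the scatter), and the change from 2,5-dichlorophenyl gives a number 12.4 percentage points higher from compound 1 to compound 3 (beyond the scatter). Chlorine is therefore not required at this position: compound 3 carries none and has the highest number of the three, with both of its steps beyond the scatter. Nothing measured here accounts for the size of these steps.

The compounds shown leave open whether the gain belongs to the methoxy group itself or to where it sits on the ring. A plain phenyl, a 2-methoxyphenyl or a 4-chlorophenyl on the same nitrogen would help to separate these two readings.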